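The source may report more compounds than this note shows. Statements on the series, on what has been measured and on what is new or still open speak of the compounds shown alone.

Measured to date in a functional assay on MDA-MB-231 cells (Homo sapiens) for antiproliferative activity, read by XTT assay, with a stated time of 72 h; on this read-out lower numbers stand for stronger inhibition and higher numbers for weaker inhibition:
- compound 1 `COc1ccc(-c2cc3ccccc3nc2/C=C/C(=O)c2ccc(O)cc2)cc1` gives 6350 nM
- compound 2 `COc1ccc(C(=O)/C=C/c2nc3ccccc3cc2-c2ccc(OC)cc2)cc1` gives 7540 nM
- compound 3 `COc1ccc(-c2cc3ccccc3nc2/C=C/C(=O)c2ccco2)cc1` gives 630 nM

Compound 3 stands lowest of the three numbers in this assay. Its nearest neighbour is compound 1, the step of a 10-fold lower number from compound 1 to compound 3 (1.00 log units; beyond the scatter); the furthest is compound 2, the step of a 12-fold lower number from compound 2 to compound 3 (1.08 log units; beyond the scatter). Compounds 1 and 2 differ only by a 1.2-fold higher number from compound 1 to compound 2 (0.07 log units; within the scatter).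

The next member, compound 4 `COc1ccc(-c2cc3ccccc3nc2/C=C/C(=O)c2ccc(Br)s2)cc1`, differs from compound 3 by 5-bromothiophen-2-yl in place of furan-2-yl on a carbonyl carbon. Going by the values given here, no measured step covers this exact exchange. Both measured steps that alter the group on the carbonyl carbon, from compound 1 and from compound 2 to compound 3, lowered the number when a five-membered aromatic ring with one hetero atom replaced a six-membered ring; the new group keeps that ring type and adds a bromine. The expectation is therefore that compound 4 stays close to compound 3, with the step of a 1.3-fold higher number from compound 3 to compound 4 (0.10 log units; within the scatter) estimated to fall within the scatter. Compound 4 is estimated at 800 nM in this assay, with a range from 250 nM to 2500 nM.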

Compound 4, half-maximal inhibitory concentration: < 100 nM
Compound 4 was reported as a limit (the forecaster's own chance of this, stated with the estimate: 5%); at least 8.0-fold (0.90 log units) between middle value and limit.
By their numbers in this assay, from the lowest: compound 3; then compounds 1 and 2 (each within the scatter of the next). At a limit, below all of these: compound 4.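

In this assay the result for compound 4 is a limit and not a number: the limit of < 100 nM in this assay, at which 1 of the 4 values shown sits. Ring type alone does not settle the number at this position, since furan-2-yl and 5-bromothiophen-2-yl are each one five-membered aromatic ring with 1 hetero atom, yet the exchange gives an at least 6.3-fold lower number from compound 3 to compound 4 (0.79 log units; beyond the scatter). The two six-membered groups on the carbonyl carbon also lie well clear of the new group, with an at least 63-fold lower number from compound 1 to compound 4 (1.80 log units; beyond the scatter) and an at least 75-fold lower number from compound 2 to compound 4 (1.87 log units; beyond the scatter).

The exchange swaps ring oxygen for sulfur and adds bromine in one step, so the compounds shown do not tell which of the two changes carries the step, and the full size of that step stays open at the limit. A thiophen-2-yl group or a 5-bromofuran-2-yl group on the same carbonyl carbon would separate the two changes.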